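Changing the Ring on the Double-Bonded Carbon

A few compounds are considered here, and "the series" means these few. Any claim that something is new, unique, unknown or untested is made for them only; others in the source may bear on it.

Compound 1, `Oc1ccc(/C=N/N(Cc2ccccc2)Cc2ccccc2)cc1`: 2400 nM
Compound 2, `Clc1ccc(/C=N/N(Cc2ccccc2)Cc2ccccc2)s1`: 170 nM

Both compounds were tested in an assay on liver (Sus scrofa) for inhibition of glucose-6-phosphatase catalytic subunit 1 (Homo sapiens), using microsomes; a lower number here means a stronger inhibitor, a higher number a weaker inhibitor. Among the measured compounds shown here, compound 2 has the lower of the two numbers, and the only measured step is a 14-fold lower number from compound 1 to compound 2 (1.15 log units; beyond the scatter), which came with 5-chlorothiophen-2-yl in place of 4-hydroxyphenyl on the carbon with a double bond to nitrogen.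

Compound 3, `OCc1ccc(/C=N/N(Cc2ccccc2)Cc2ccccc2)o1`, has not yet been measured. It differs from compound 2 in one place: 5-(hydroxymethyl)furan-2-yl in place of 5-chlorothiophen-2-yl on a carbon with a double bond to nitrogen. For the measured compounds named here, the single measured step bears directly on this change, as it also swaps the ring on the same carbon. There, the ring carrying a hydroxyl group gave the higher number, and compound 3 again brings in a hydroxyl group, now as a hydroxymethyl on a furan ring. A higher number than compound 2 is therefore expected in this assay, though the five-membered ring is kept, so a smaller rise than in the measured step seems likely.

For compound 3 the expected value is 800 nM, with a range from 250 nM to 3500 nM. The step this estimate implies, a 4.7-fold higher number from compound 2 to compound 3 (0.67 log units; beyond the scatter), is an expectation only.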

Compound 3, half-maximal inhibitory concentration: 16000 nM
The estimate for compound 3 lay 20-fold (1.30 log units) below the measured number; the measured number lies above the stated range.
By their numbers in this assay, from the lowest: compound 2; then compound 1; then compound 3.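

In this assay, keeping a five-membered aromatic ring with one hetero atom on the carbon with a double bond to nitrogen did not keep the number low, since 5-(hydroxymethyl)furan-2-yl in place of 5-chlorothiophen-2-yl gave a 94-fold higher number from compound 2 to compound 3 (1.97 log units; beyond the scatter). The same group also ranks behind 4-hydroxyphenyl, with a 6.7-fold higher number from compound 1 to compound 3 (0.82 log units; beyond the scatter), so among these three compounds a five-membered ring does not by itself give a lower number than 4-hydroxyphenyl, and the choice of group at this position spreads the numbers widely, with each step beyond the usual scatter. Nothing available explains why these groups differ so strongly in this assay.

Compound 2 and compound 3 differ in both the ring's hetero atom, sulfur against oxygen, and the group it carries, chlorine against hydroxymethyl, so the compounds shown cannot tell which of the two changes accounts for the rise. From the compounds shown here alone, a 5-chlorofuran-2-yl or a 5-(hydroxymethyl)thiophen-2-yl group would pull those two changes apart, and how an amine or a carboxylic acid on the ring would fare also remains open.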